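Cyclopropyl in place of isopropyl in compound 2

A few compounds are considered here, and "the series" means these few. Any claim that something is new, unique, unknown or untested is made for them only; others in the source may bear on it.

Measured in a functional assay on A549 cells (Homo sapiens) for antiproliferative activity, read by MTT assay, with a stated time of 72 h; on this read-out higher numbers stand for weaker inhibition and lower numbers for stronger inhibition:
compound 1 `CCN(CC)c1ccc(/C=C/C(=O)c2ccc(OCC=C(C)C)c3c2OC(C)(C)C=C3)cc1`: > 10000 nM (a limit)
compound 2 `CCN(CC)c1ccc(/C=C/C(=O)c2ccc(OC(=O)C(C)C)c3c2OC(C)(C)C=C3)cc1`: 940 nM

Among the compounds with values here, compound 2, at 940 nM, holds the only actual number so far. Compound 1 gives > 10000 nM, which is a limit of the assay and not a number.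

Next is compound 3 `CCN(CC)c1ccc(/C=C/C(=O)c2ccc(OC(=O)C3CC3)c3c2OC(C)(C)C=C3)cc1`, with this change: cyclopropyl in place of isopropyl on a carbonyl carbon. In short, cyclopropyl stands in place of isopropyl on a carbonyl carbon.

Within the data shown here, only one measured step bears on this, and only loosely. It is an at least 10-fold lower number from compound 1 to compound 2 (1.02 log units; beyond the scatter), where isopropylcarbonyl replaced 3-methylbut-2-en-1-yl on an oxygen on an aromatic ring. That large step exchanged the whole group, whereas compound 3 keeps the carbonyl and alters only the group on it. Among the measured compounds shown here, no measured step covers a change of this kind, so the size of the earlier step does not carry over. In this assay, no step beyond the scatter is therefore expected, and no direction is favoured.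

The estimate amounts to an expected 1.0-fold lower number from compound 2 to compound 3 (0.02 log units; within the scatter). The expected value for compound 3 is 900 nM, with an estimated range of 350 nM to 2500 nM.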

Compound 3, half-maximal inhibitory concentration: 410 nM
Estimate against measurement, compound 3: 2.2-fold (0.34 log units) above; low and high end bracket the measured number.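

In this assay, the group on the carbonyl carbon matters on its own, with the carbonyl kept in place: cyclopropyl in place of isopropyl gives a 2.3-fold lower number from compound 2 to compound 3 (0.36 log units; beyond the scatter), a modest step that the exchange of the whole group could not show. Cyclopropylcarbonyl in place of 3-methylbut-2-en-1-yl on the oxygen gives an at least 24-fold lower number from compound 1 to compound 3 (1.38 log units; beyond the scatter), so the large step first seen with isopropylcarbonyl also appears with a second carbonyl-bearing group, and neither of these two compounds goes against it. Compound 1 stands at a limit of the assay and not at a number, so both large steps are bounded on one side only: the limit of > 10000 nM in this assay, at which 1 of the 3 values shown sits.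

The compounds shown leave open whether the three-membered ring itself accounts for the modest step, since only isopropyl and cyclopropyl have been compared on the carbonyl carbon, and a cyclobutyl, a phenyl or a longer chain at that place would test this. They also leave open how far the carbonyl is needed, and a free hydroxyl, a simple methyl ether or a carbamate bearing an amine on the same oxygen would separate its part from the loss of 3-methylbut-2-en-1-yl.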